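This account rests on a few compounds, and the source may have more. Where it says the series, first, only, none or still open, it means among the compounds named here.

Measured compounds:
Compound 1 `C/C(=C\CC/C(C)=C/CC[C@@H]1[C@@]2(C)CCC(=O)C(C)(C)[C@H]2CC[C@@]1(C)O)CC/C=C(\C)C(=O)OCc1cn(-c2ccc(F)cc2)nn1` — in a functional assay on A549 cells (Homo sapiens) for antiproliferative activity, read by MTT assay, with a stated time of 48 h (on this read-out higher numbers stand for weaker inhibition and lower numbers for stronger inhibition), compound 1 gives > 150000 nM, which is a limit of the assay rather than a number.
Compound 2 `C/C(=C\CC/C(C)=C/CC[C@@H]1[C@@]2(C)CCC(=O)C(C)(C)[C@H]2CC[C@@]1(C)O)CC/C=C(\C)C(=O)OCc1cn(C[C@@H]2O[C@H](n3ccc(=O)[nH]c3=O)C[C@H]2O)nn1` — in this assay compound 2 gives 28100 nM.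
Compound 3 `C/C(=C\CC/C(C)=C/CC[C@@H]1[C@@]2(C)CCC(=O)C(C)(C)[C@H]2CC[C@@]1(C)O)CC/C=C(\C)C(=O)O` — in this assay compound 3 gives > 150000 nM, again a limit of the assay.

Compound 1 therefore stands at the weak end of what was measured: it reaches only (the limit of > 150000 nM in this assay, at which 2 of the 3 values shown sit), and the same is true of compound 3. Only compound 2 returns an actual number. Among the compounds with values here, no pair of measured compounds differs in a single place, so no measured step can be followed; the values show only that the ester with the sugar-bearing group gives a number while the other two do not.

Compound 4 `C/C(=C\CC/C(C)=C/CC[C@@H]1[C@@]2(C)CCC(=O)C(C)(C)[C@H]2CC[C@@]1(C)O)CC/C=C(\C)C(=O)OCc1cn(-c2cccc(Br)c2)nn1` is not yet measured. It differs from compound 1 in one place: 3-bromophenyl in place of 4-fluorophenyl on an aromatic nitrogen. With compound 1 resting at a limit, the step from compound 1 to compound 4 is expected to be a number no higher from compound 1 to compound 4 (the limit leaves the size open), nothing beyond the usual scatter. Compound 4 is therefore estimated at 150000 nM, in a range from 50000 nM to 400000 nM, and most likely the assay will again report only a limit.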

Compound 4, half-maximal inhibitory concentration: > 150000 nM
Compound 4 was reported as a limit; the forecaster's own chance of this, stated with the estimate: 70%; the middle value sits exactly at the limit.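

Compound 1 and compound 4 each give only a limit of the assay, so no step between them can be read: the limit of > 150000 nM in this assay, at which 3 of the 4 values shown sit.

The compounds shown leave open whether 3-bromophenyl in place of 4-fluorophenyl changes anything in this assay, where neither compound returns an actual number.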